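A few compounds are considered here, and "the series" means these few. Any claim that something is new, unique, unknown or untested is made for them only; others in the source may bear on it.

In a functional assay on FM3A cells (Mus musculus) for cytotoxicity (on this read-out higher numbers stand for an effect only at larger amounts of compound and lower numbers for an effect already at smaller amounts), compound 2 `CCCCOOC1(OOC)CCCCCCCCCCC1` gives 20000 nM. Compound 1 `CCCCOOC1(OOCCCC)CCCCCCCCCCC1` gives 8500 nM, which places it lower, with a 2.4-fold higher number from compound 1 to compound 2 (0.37 log units; beyond the scatter). Compound 3 `COOC1(OOCCCc2ccccc2)CCCCCCCCCCC1` gives 34000 nM, and a 1.7-fold higher number from compound 2 to compound 3 (0.23 log units; within the scatter), so compound 2 and compound 3 cannot be told apart on these numbers.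

Compound 4 `COOC1(OOC(C)(C)OC)CCCCCCCCCCC1` has not yet been measured. It carries 1-methoxy-1-methylethyl in place of butyl on an oxygen. For the measured compounds named here, no measured compound carries this new group, so no step speaks to it directly. The closest guides are the two steps that altered a chain in this small series. One was modest, at a 2.4-fold higher number from compound 1 to compound 2 (0.37 log units; beyond the scatter), and the other stayed within the scatter, at a 1.7-fold higher number from compound 2 to compound 3 (0.23 log units; within the scatter). Swapping chains has so far moved the number only a little, so no clear shift in either direction is expected here. The expected step is a 1.1-fold lower number from compound 2 to compound 4 (0.05 log units; within the scatter), which would stay within the scatter. For compound 4 the estimated value is 18000 nM, with an expected range from 7000 nM to 45000 nM.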

Compound 4, half-maximal effective concentration: 7300 nM
Compound 4: middle estimate off by 2.5-fold (0.39 log units), on the high side; the measured number falls inside the stated range.
By their numbers in this assay, from the lowest: compounds 4 and 1 (each within the scatter of the next); then compounds 2 and 3 (each within the scatter of the next).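

In this assay, putting 1-methoxy-1-methylethyl in place of butyl on an oxygen whose other neighbours are oxygen gives a 2.7-fold lower number from compound 2 to compound 4 (0.44 log units; beyond the scatter), so a change at this position can shift the effect towards smaller amounts of compound. The earlier steps shown here swapped one carbon-and-hydrogen group for another, whereas this one brings in a group with an oxygen of its own, going from no hydrogen-bond acceptors to one. Nothing measured here explains why the number moved.

The compounds shown do not separate the part played by the methoxy oxygen from that of the carbon carrying the two methyl groups. As far as these compounds go, a comparison with tert-butyl or 2-methoxyethyl on the same oxygen would pull these two features apart, and whether an amine there behaves similarly remains open.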